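This account rests on a few compounds, and the source may have more. Where it says the series, first, only, none or still open, it means among the compounds named here.

Measured so far:
Compound 1, `COc1cc(NC(=O)Nc2cc(Nc3ccc(C(C)(C)C)cc3)ncn2)cc(OC)c1`: 74.1%
Compound 2, `Cc1ccc(Nc2cc(NC(=O)Nc3c(Cl)cccc3Cl)ncn2)cc1F`: 92%
Compound 3, `CCc1ccc(Nc2cc(NC(=O)Nc3cc(OC)cc(OC)c3)ncn2)cc1`: 78%

In a functional assay on PC-9 cells (Homo sapiens) for inhibition, read by MTT assay, with a stated time of 48 h, tested at 10 uM (a higher number here means more inhibition at the concentration tested (going by the name of the read-out), a lower number less inhibition), compound 2 stands highest of the three numbers; compound 3 is nearest, and compound 1 furthest, both beyond the scatter below it. Compound 4, `COc1ccc(F)cc1Nc1cc(NC(=O)Nc2c(Cl)cccc2Cl)ncn1`, has not yet been measured. It differs from compound 2 in one place: 5-fluoro-2-methoxyphenyl in place of 3-fluoro-4-methylphenyl on a nitrogen on an aromatic ring.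

Going by the values given here, only one measured step exists, a number 3.9 percentage points higher from compound 1 to compound 3 (within the scatter), and it concerns a group on a different aromatic ring, attached to the same kind of nitrogen, so it does not bear directly on the change from compound 2 to compound 4. Among the compounds with values here, no measured step alters the group that changes here, and compounds 1 and 3 carry a different urea partner than compound 2, so they give no guide either. With nothing pointing to a move beyond the scatter, a small step, if any, is expected in this assay, estimated as a number 7 percentage points lower from compound 2 to compound 4 (within the scatter). Compound 4 is therefore expected to give about 85%, within a range from 65% to 97%.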

Compound 4, a percentage reported as inhibition, at one concentration (the size of the read-out at that concentration, not a potency): 85.5%
Estimate against measurement, compound 4: 0.5 percentage points below, within the range that was stated.
By their numbers in this assay, from the lowest: compounds 1, 3, 4 and 2 (each within the scatter of the next, the first and the last beyond it).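

Replacing 3-fluoro-4-methylphenyl with 5-fluoro-2-methoxyphenyl on this nitrogen gives, in this assay, a number 6.5 percentage points lower from compound 2 to compound 4 (within the scatter). Going by these compounds alone, this is the first measured change to this group with the urea partner of compound 2 held fixed, and it shows that the position can take a differently substituted phenyl ring carrying an oxygen-linked methoxy group while the numbers stay within the scatter of each other. Nothing measured here offers a reason for this result.

Because the substituents on the ring differ at once, this single step cannot separate the part played by the methoxy group from that of the methyl group or the fluorine. Also open, on these data alone, is how this position would respond to a phenyl ring bearing an amine or a carboxylic acid, and whether compound 2 and compound 4 would differ in potency across a range of concentrations.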